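This account rests on a few compounds, and the source may have more. Where it says the series, first, only, none or still open, it means among the compounds named here.

Measured in a functional assay on MGC-803 cells (Homo sapiens) for inhibition, read by sulforhodamine B assay; a lower number here means a stronger inhibitor, a higher number a weaker inhibitor:
- compound 1 `O=C1C=C(Nc2cccc(F)c2)C(=O)c2c1nc1n2[C@H]2OC[C@@H](O)[C@H]2OC1`: 2180 nM
- compound 2 `COc1ccc(NC2=CC(=O)c3c(nc4n3[C@H]3OC[C@@H](O)[C@H]3OC4)C2=O)cc1`: 2150 nM
- compound 3 `O=C1C(N2CCC2)=CC(=O)c2c1nc1n2[C@H]2OC[C@@H](O)[C@H]2OC1`: > 16000 nM

Compound 1 gives 2180 nM, within the scatter of compound 2. The entry for compound 3 is only a limit, > 16000 nM.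

Compound 4 `CCOc1ccccc1NC1=CC(=O)c2nc3n(c2C1=O)[C@H]1OC[C@@H](O)[C@H]1OC3` carries 2-ethoxyphenyl in place of 3-fluorophenyl on an amine nitrogen. Among the compounds with values here, the one measured step is an at least 7.4-fold higher number from compound 2 to compound 3 (0.87 log units; beyond the scatter), with azetidin-1-yl in place of (4-methoxyphenyl)amino, and it bears only weakly, as compound 4 keeps a phenyl ring on that nitrogen. Closer evidence is compound 2 at 2150 nM, level with compound 1 despite a different phenyl group. No step beyond the scatter is therefore expected in this assay, and the estimated step is a 1.1-fold higher number from compound 1 to compound 4 (0.06 log units; within the scatter). For compound 4 the expected value is 2500 nM, with an estimated range from 1000 nM to 6500 nM.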

Compound 4, half-maximal inhibitory concentration: 2450 nM
For compound 4 the middle estimate is 1.0-fold (0.01 log units) above the measured one, within the range that was stated.
By their numbers in this assay, from the lowest: compounds 2, 1 and 4 (each within the scatter of the next). At a limit, above all of these: compound 3.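

With a 1.1-fold higher number from compound 1 to compound 4 (0.05 log units; within the scatter) in this assay, the amine nitrogen on the double-bonded ring carbon takes 2-ethoxyphenyl, with 9 heavy atoms and 1 hydrogen-bond acceptor, in place of 3-fluorophenyl, with 7 heavy atoms and none, without a step beyond the scatter. Here the oxygen-bearing group and the fluorine-bearing group sit on the same core and differ in size, and the number holds level.

Going by these compounds, it remains open whether a phenyl ring bearing a carboxylic acid or an amine would hold that level on this nitrogen. Compound 3 gives only a limit, so the size of its step stays unknown: the limit of > 16000 nM in this assay, at which 1 of the 4 values shown sits.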